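Adding a second methyl to compound 2

A few compounds are considered here, and "the series" means these few. Any claim that something is new, unique, unknown or untested is made for them only; others in the source may bear on it.

Compound 1 `CC(C)=CCOc1ccc2c(c1)OC(c1cccc(Cl)c1)CC2=O`: 6300 nM
Compound 2 `CC(C)=CCOc1ccc2c(c1)OC(c1ccc(C)cc1)CC2=O`: 4440 nM

Both values come from a functional assay; a lower number here means a stronger inhibitor, a higher number a weaker inhibitor. Going by the values given here, with only two compounds measured, compound 2 at 4440 nM stands level with compound 1 within the usual scatter. The next compound, compound 3 `CC(C)=CCOc1ccc2c(c1)OC(c1ccc(C)cc1C)CC2=O`, differs from compound 2 in one place: methyl in place of hydrogen on an aromatic carbon. This is methyl in place of hydrogen on an aromatic carbon, turning 4-methylphenyl into 2,4-dimethylphenyl. Among the compounds with values here, only one measured step bears on it: a 1.4-fold lower number from compound 1 to compound 2 (0.15 log units; within the scatter). Within the data shown here, that step exchanged 3-chlorophenyl for 4-methylphenyl, so it is indirect evidence, and no measured compound has a group at the new place. No step beyond the scatter is therefore expected in this assay, and neither direction is favoured. The expected change is a 1.1-fold lower number from compound 2 to compound 3 (0.02 log units; within the scatter). Compound 3 is estimated at 4200 nM, with an expected range of 1800 nM to 10000 nM.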

Compound 3, half-maximal inhibitory concentration: 8260 nM
Estimate against measurement, compound 3: 2.0-fold (0.29 log units) below; the range from low to high includes it.
By their numbers in this assay, from the lowest: compounds 2, 1 and 3 (each within the scatter of the next).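

Going by these compounds alone, this is the first compound with a group at this place, ortho to a large group, and in this assay the added methyl gives a 1.9-fold higher number from compound 2 to compound 3 (0.27 log units; within the scatter) so a methyl here produces no change that can be told apart from the scatter. Comparing the whole group on the saturated ring carbon, 2,4-dimethylphenyl in place of 3-chlorophenyl gives a 1.3-fold higher number from compound 1 to compound 3 (0.12 log units; within the scatter) and so also stays within the scatter, which leaves these three aryl groups undistinguished in this measurement. Nothing further is available to help interpret this result.

Going by these compounds, whether a different group at this same place, such as an amine, a carboxylic acid or a longer chain, would give a step beyond the scatter remains open. So does whether a change elsewhere on the shared core would do so.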